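The compounds below may be only part of what the source reports. "The series", "measured", "known", "first", "only" and "open" are said of these compounds alone.

Measured compounds:
- compound 1 `NC1=NC2(CCOCC2)N(OCCCOc2ccc(F)cc2)C(N)=N1`: "not determined" (no result reported)
- compound 2 `NC1=NC2(CCOCC2)N(OCCCOc2cc(Cl)c(Cl)cc2Cl)C(N)=N1`: "not determined" (no result reported)
- compound 3 `NC1=NC2(CCSCC2)N(OCCCOc2cccc(Cl)c2Cl)C(N)=N1`: 1 nM

Within the data shown here, in a functional assay on MDA-MB-231 cells (Homo sapiens) for antiproliferative activity, read by MTT assay, with a stated time of 72 h (on this read-out lower numbers stand for stronger inhibition and higher numbers for weaker inhibition), compound 3 gives 1 nM, the only number in the set; for compound 1 and compound 2 no result was reported in this assay, so there is no measured step against which a change on the aryl group can be gauged. Compound 3 therefore stands alone and cannot be ranked.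

The next compound is compound 4 `NC1=NC2(CCSCC2)N(OCCCOc2ccc(Br)cc2)C(N)=N1`. It differs from compound 3 in one place: 4-bromophenyl in place of 2,3-dichlorophenyl on an oxygen on a saturated carbon. The shared core of compound 3 and compound 4 is kept unchanged; only the aryl group on the oxygen changes.

Among the measured compounds shown here, with no comparable step in hand, the expectation rests on compound 3 alone. The starting point is very low, so a move to weaker inhibition is more likely than a move to stronger. A small loss, close to the scatter, is expected; the step is estimated as a 3.0-fold higher number from compound 3 to compound 4 (0.48 log units; beyond the scatter). Compound 4 is expected to give about 3 nM in this assay. The estimated range for compound 4 runs from 0.6 nM to 20 nM.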

Compound 4, half-maximal inhibitory concentration: 440 nM
Beside the measured number, compound 4's estimate is 150-fold (2.17 log units) below it, and the stated range ends below it.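

In this assay, the aryl group on the oxygen on a saturated carbon now shows a strong bearing on the read-out: 4-bromophenyl in place of 2,3-dichlorophenyl gives a 440-fold higher number from compound 3 to compound 4 (2.64 log units; beyond the scatter), a large step beyond the scatter. Among these compounds, the earlier compounds gave no measured step at this position, so this pair is the first sign that, with the shared core unchanged, the aryl groups here are not interchangeable. Nothing at hand bears on the cause of a step of this size.

This single pair exchanges the whole aryl group, so the loss of chlorine cannot be separated from the entry of bromine. Going by these compounds, how a plain phenyl, a pyridine ring or a longer chain in place of the three-carbon linker would read remains open.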